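A few compounds are considered here, and "the series" means these few. Any claim that something is new, unique, unknown or untested is made for them only; others in the source may bear on it.

Measured so far in an ADME assay on microsomes from liver (Homo sapiens) for metabolic stability, read by LC-MS, with a stated time of 30 min, tested at 1 uM; a higher number here means that more of the compound is left, a lower number that less of the compound is left:
- Compound 1 `O=C(NCc1ccc(S(=O)(=O)c2ccccc2)cc1)c1cc2ccncc2s1`: 48%
- Compound 2 `O=C(NCc1ccc(S(=O)(=O)c2ccccc2)cc1)c1nc2ccncc2s1`: 68%
- Compound 3 `O=C(NCc1ccc(S(=O)(=O)c2ccccc2C(F)(F)F)cc1)c1cc2cnccc2[nH]1`: 52%

Compound 3, at 52%, cannot be told apart from compound 1, at 48%, since the two lie within the usual scatter. Compound 2, at 68%, stands beyond the scatter above both.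

Compound 4 `O=C(NCc1ccc(S(=O)(=O)c2ccccc2)cc1)c1cc2cnccc2[nH]1` keeps the core of compound 3 and changes one place: hydrogen in place of trifluoromethyl on an aromatic carbon. In words, this is hydrogen in place of trifluoromethyl on an aromatic carbon, so 2-(trifluoromethyl)phenyl becomes phenyl.

Within the data shown here, only one measured step exists, a number 20 percentage points higher from compound 1 to compound 2 (beyond the scatter), and it is a modest one. It swaps the group on the carbonyl carbon and does not touch the trifluoromethyl, so it bears on this change only indirectly. It shows that a single exchange in this series can move this assay beyond the scatter. Among the measured compounds shown here, no measured pair isolates the loss of trifluoromethyl, so neither a direction nor a size can be read from the data. Compound 1 and compound 2 already carry the plain phenyl, and their values bracket compound 3 without pointing either way.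

The expected result is therefore no change beyond the scatter, with a number 1 percentage points lower from compound 3 to compound 4 (within the scatter) as the estimated step. For compound 4 the estimate is 51%, with an expected range from 35% to 68%.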

Compound 4, percent of the compound remaining: 75%
Beside the measured number, compound 4's estimate is 24 percentage points below it; measured number above the stated range.
By their numbers in this assay, from the lowest: compounds 1 and 3 (each within the scatter of the next); then compounds 2 and 4 (each within the scatter of the next).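

In this assay, among these compounds, replacing trifluoromethyl with hydrogen, so that 2-(trifluoromethyl)phenyl becomes phenyl, gives a number 23 percentage points higher from compound 3 to compound 4 (beyond the scatter); this is the first measured sign that this place, on an aromatic carbon ortho to a large group, can move the read-out beyond the scatter. With the phenyl kept, the group on the carbonyl carbon also counts, but not for every exchange: one exchange gives a number 27 percentage points higher from compound 1 to compound 4 (beyond the scatter), while another gives a number 7 percentage points higher from compound 2 to compound 4 (within the scatter), so only the first of these two separates the compounds. Nothing measured here explains why removing trifluoromethyl or exchanging the group on the carbonyl carbon shifts the amount of compound left.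

The compounds shown do not tell whether the result depends on trifluoromethyl itself or would also appear with another group at this place, such as methoxy or a lone fluorine atom. From the compounds shown here alone, it also remains open whether adding trifluoromethyl to compound 1 or compound 2 would lower the number in this assay as it does on the core shared by compound 3 and compound 4.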